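Acylating the aniline nitrogen of a weak antiproliferative

This account rests on a few compounds, and the source may have more. Where it says the series, first, only, none or still open, it means among the compounds named here.

Compound 1 `Nc1cccc(-c2cn3nc(Cc4ccc(Cl)cc4)sc3n2)c1` – 25000 nM
Compound 2 `COc1ccc(Cc2nn3cc(-c4cccc(N)c4)nc3s2)cc1` – 191000 nM

In a functional assay on HeLa cells (Homo sapiens) for inhibition, read by cell counting, with a stated time of 4 days (on this read-out lower numbers stand for stronger inhibition and higher numbers for weaker inhibition), compound 1 gives 25000 nM. Within the data shown here, compound 2 gives 191000 nM and so stands with the highest number of the two measured; the only measured step, a 7.6-fold higher number from compound 1 to compound 2 (0.88 log units; beyond the scatter), separates it from compound 1.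

Compound 3 `C=C(Br)C(=O)Nc1cccc(-c2cn3nc(Cc4ccc(OC)cc4)sc3n2)c1` differs from compound 2 by (1-bromoethenyl)carbonyl in place of hydrogen on a nitrogen on an aromatic ring. Among the measured compounds shown here, no measured step concerns an acyl group on this nitrogen; the one step measured, a 7.6-fold higher number from compound 1 to compound 2 (0.88 log units; beyond the scatter), changes a substituent on the distant benzyl ring and does not bear on the present change. The expectation therefore rests on little, and a wide range is appropriate. Compound 3 is estimated at 60000 nM, with a range of 8000 nM to 250000 nM, which means an expected step of a 3.2-fold lower number from compound 2 to compound 3 (0.50 log units; beyond the scatter) in this assay.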

Compound 3, half-maximal inhibitory concentration: 2300 nM
Compound 3: middle estimate off by 26-fold (1.42 log units), on the high side, outside the stated range (below it).
By their numbers in this assay, from the lowest: compound 3; then compound 1; then compound 2.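

In this assay, the amino group of compound 2 is not required for activity: the change from amino to ((1-bromoethenyl)carbonyl)amino gives an 83-fold lower number from compound 2 to compound 3 (1.92 log units; beyond the scatter). The earlier step, a 7.6-fold higher number from compound 1 to compound 2 (0.88 log units; beyond the scatter), concerned only a substituent on the benzyl ring, whereas this result shows that the nitrogen on an aromatic ring is also a position where the read-out can shift strongly. Nothing available explains why this acylation has so large an effect.

The compounds shown do not separate the contributions of the carbonyl, the bromine and the double bond, which a plain acetyl or acryloyl group on the same nitrogen would help to distinguish. They also leave open whether the same acylation would give a comparable step with chloro in place of methoxy on the benzyl ring.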